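The source may hold more compounds than are shown below. What is called first, only, known or untested is meant among the compounds shown, and "the series" means these compounds.

Compound 2, `Cn1nnnc1SCC(=O)Nc1ccc(-c2nc(-c3ccccc3)c(-c3ccccc3)n2C)cc1`, gives 63.7% in a functional assay on MCF7 cells (Homo sapiens) for cytotoxicity, read by MTT assay, with a stated time of 24 h, tested at 16 ug/mL (on this read-out lower numbers stand for a weaker effect and higher numbers for a stronger effect at the one concentration tested), and so stands highest of the two numbers in hand. Among the compounds with values here, its nearest neighbour is compound 1, `Cc1ccc2oc(SCC(=O)Nc3ccc(-c4nc(-c5ccccc5)c(-c5ccccc5)n4C)cc3)nc2c1`, which in this assay gives 40.3%; the one measured step is a number 23.4 percentage points higher from compound 1 to compound 2 (beyond the scatter), a modest rise that goes beyond the scatter. Compound 3, `CCN1CCN(CC(=O)Nc2ccc(-c3nc(-c4ccccc4)c(-c4ccccc4)n3C)cc2)CC1`, is compared here with compound 2. The change is 4-ethylpiperazin-1-yl in place of (1-methyl-1H-tetrazol-5-yl)sulfanyl on a saturated chain carbon bound to a carbonyl carbon. Within the data shown here, the single measured step exchanged one ring for another on the sulfur, while the change to compound 3 removes the sulfur together with its ring and brings in a saturated ring in their place, so that step gives no direct guide to what follows. Among the measured compounds shown here, with no measured step bearing on this change, the direction is open; a step of any size beyond the scatter in this assay cannot be ruled out, and none is firmly expected. Compound 3 is therefore estimated at 50%, within a range from 25% to 75%, which corresponds to an expected step of a number 13.7 percentage points lower from compound 2 to compound 3 (beyond the scatter).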

Compound 3, a percentage reported as activity, at one concentration (the size of the read-out at that concentration, not a potency): 32.8%
Compound 3: middle estimate off by 17.2 percentage points, on the high side; the measured number falls inside the stated range.
By their numbers in this assay, from the lowest: compounds 3 and 1 (each within the scatter of the next); then compound 2.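

In this assay, the step of a number 30.9 percentage points lower from compound 2 to compound 3 (beyond the scatter) shows that this position tolerates more than an exchange of rings on the sulfur, yet that giving up (1-methyl-1H-tetrazol-5-yl)sulfanyl for 4-ethylpiperazin-1-yl on the saturated chain carbon bound to a carbonyl carbon does not keep the number of the tetrazole compound. The second comparison, a number 7.5 percentage points lower from compound 1 to compound 3 (within the scatter), puts 4-ethylpiperazin-1-yl level with (5-methyl-1,3-benzoxazol-2-yl)sulfanyl, so that among these three groups only the tetrazole-bearing one stands apart, beyond the scatter from both others. Nothing at hand bears on why the numbers fall this way.

The compounds shown leave open whether the higher number of compound 2 goes with the tetrazole ring, with the sulfur link, or with the two together, and a tetrazole attached without sulfur would be needed to separate them. They also leave open how far the saturated ring itself matters, which a morpholine, a 4-methylpiperazin-1-yl group or an open-chain amine such as dimethylamino on the same carbon would begin to show.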